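This account rests on a few compounds, and the source may have more. Where it says the series, first, only, none or still open, it means among the compounds named here.

Measured compounds:
compound 1 `COc1c(NS(=O)(=O)c2ccc(F)cc2)cc(-c2ccc3nc(NC4CC4)sc3n2)cc1C(N)=O` gives 33100 nM
compound 2 `COc1c(NS(=O)(=O)c2ccc(F)cc2)cc(-c2ccc3nc(NC(C)=O)sc3c2)cc1C(N)=O` gives 500 nM

Of the compounds shown here, two have been measured in a functional assay on MCF7 cells (Homo sapiens) for antiproliferative activity, read by MTT assay, with a stated time of 72 h; a higher number here means a weaker inhibitor, a lower number a stronger inhibitor. Compound 1 gives 33100 nM, the higher of the two numbers. Compound 2 gives 500 nM, a far lower number, and the gap between them lies beyond the scatter. Compound 2 differs from compound 1 in more than one place, so the two values can only be set side by side; what drives the gap cannot be read from them.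

Compound 3 `COc1c(NS(=O)(=O)c2ccc(F)cc2)cc(-c2ccc3nc(NC(=O)C4CC4)sc3n2)cc1C(N)=O` has not yet been measured in this assay. It keeps the core of compound 1 and changes only one thing: cyclopropylcarbonyl in place of cyclopropyl on a nitrogen on an aromatic ring. The acylated ring nitrogen that results is also a feature of compound 2, which gives the lower number in this assay, but no single-change step in either direction has been measured, and the other differences between compound 1 and compound 2 remain unresolved.

The step from compound 1 to compound 3 is expected to be a drop, a 13-fold lower number from compound 1 to compound 3 (1.12 log units; beyond the scatter), likely beyond the scatter but smaller than the full gap to compound 2. Compound 3 is therefore estimated at 2500 nM, within a range of 500 nM to 12000 nM.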

Compound 3, half-maximal inhibitory concentration: 22100 nM
Compound 3: the middle estimate sits 8.8-fold (0.95 log units) below what was measured; measured number above the stated range.
By their numbers in this assay, from the lowest: compound 2; then compounds 3 and 1 (each within the scatter of the next).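

In this assay, the exchange of cyclopropyl for cyclopropylcarbonyl on a nitrogen on an aromatic ring can now be read as a change in one place, and the step is a 1.5-fold lower number from compound 1 to compound 3 (0.18 log units; within the scatter). On the core of compound 1, this exchange adds a carbonyl and one hydrogen-bond acceptor, yet the values of compound 1 and compound 3 cannot be told apart in this measurement, so a cyclopropylamino group and a (cyclopropylcarbonyl)amino group at this place give numbers within the usual scatter of each other. No measurement offered here bears on why the two values stand so close.

Neither compound 1 nor compound 3 differs from compound 2 in only one place, so what lies behind the number of compound 2 at 500 nM cannot be read from these compounds. Also open, on these data alone, is how a urea or a longer acyl chain on this nitrogen would read in this assay, and whether the same exchange on another core would again stay within the scatter.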